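Dropping One Methyl: Effect on Breast-Cancer Cell Killing

This account rests on a few compounds, and the source may have more. Where it says the series, first, only, none or still open, it means among the compounds named here.

Compound 1, `O=Cc1c(O)ccc2oc(-c3ccco3)nc12`: in a functional assay on MDA-MB-231 cells (Homo sapiens) for cytotoxicity, read by MTT assay, with a stated time of 48 h (a higher number here means a weaker inhibitor, a lower number a stronger inhibitor), compound 1 gives > 30000 nM, which is a limit of the assay rather than a number.
Compound 2, `CC(=O)c1c(O)ccc2oc(-c3ccccc3C)nc12`: in this assay compound 2 gives 30100 nM.

Among the compounds with values here, compound 2 therefore holds the only real number in this small set; the other result, for compound 1, is a limit (the limit of > 30000 nM in this assay, at which 1 of the 2 values shown sits). Compound 3, `CC(=O)c1c(O)ccc2oc(-c3ccccc3)nc12`, differs from compound 2 in one place: hydrogen in place of methyl on an aromatic carbon. Within the data shown here, no measured pair differs in a single place, so there is no directly comparable step to lean on. So small a change is expected to move the read-out little, and the step of a 1.0-fold lower number from compound 2 to compound 3 (0.00 log units; within the scatter) is expected to lie within the usual scatter, with no clear direction. Compound 3 is thus estimated at about 30000 nM, with a plausible range from 12000 nM to 80000 nM, and it may well return only a limit, as compound 1 did.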

Compound 3, half-maximal inhibitory concentration: > 30000 nM
Compound 3 was reported as a limit; the forecaster's own chance of this, stated with the estimate: 50%; the middle value lies on the limit itself.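

In this assay compound 3 gives > 30000 nM, which is a limit of the assay and not a number, so the step from compound 2 to compound 3 cannot be read. As far as these compounds go, whether hydrogen in place of methyl shifts the read-out at all, and in which direction, stays open.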